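Piperidin-1-yl in place of (4-methylphenyl)amino

A few compounds are considered here, and "the series" means these few. Any claim that something is new, unique, unknown or untested is made for them only; others in the source may bear on it.

Compound 1 `O=C1C(Nc2ccc(Br)cc2)=CC(=O)c2c1nc1n2[C@H]2OC[C@@H](O)[C@H]2OC1` gives 4330 nM in a functional assay on MCF7 cells (Homo sapiens) for inhibition, read by sulforhodamine B assay; on this read-out higher numbers stand for weaker inhibition and lower numbers for stronger inhibition
Compound 2 `Cc1ccc(NC2=CC(=O)c3c(nc4n3[C@H]3OC[C@@H](O)[C@H]3OC4)C2=O)cc1` gives > 4000 nM in this assay (a limit)

Compound 2 has no number of its own and stands only at a limit, > 4000 nM. This is the case recorded in the limit of > 4000 nM in this assay, at which 1 of the 2 values shown sits.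

Compound 3 `O=C1C(N2CCCCC2)=CC(=O)c2c1nc1n2[C@H]2OC[C@@H](O)[C@H]2OC1` differs from compound 2 at a single place: piperidin-1-yl in place of (4-methylphenyl)amino on a double-bonded ring carbon. In words, piperidin-1-yl stands in place of (4-methylphenyl)amino on a double-bonded ring carbon.

Among the compounds with values here, only one measured step bears on this, a step that the limit leaves unreadable from compound 1 to compound 2. It changes a group on an aromatic carbon, and its size cannot be read. It leaves no size or direction to carry over, so no step beyond the scatter is expected in this assay. The expected step is a step that the limit leaves unreadable from compound 2 to compound 3. For compound 3 the estimated value is 5000 nM, with an expected range from 1800 nM to 15000 nM.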

Compound 3, half-maximal inhibitory concentration: > 8000 nM
Compound 3: only a limit was reported; the forecaster's own chance of this, stated with the estimate: 45%; middle value at least 1.6-fold (0.20 log units) away from the limit.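

In this assay, within the data shown here, the change at the double-bonded ring carbon from (4-bromophenyl)amino to piperidin-1-yl gives an at least 1.8-fold higher number from compound 1 to compound 3 (0.26 log units; that floor lies within the scatter), so this is the first readable step at this position, and it shows no stronger inhibition with a ring that has no hydrogen-bond donor and no aromatic ring. Compound 3 has no number of its own and stands only at a limit: the limit of > 8000 nM in this assay, at which 1 of the 3 values shown sits. The steps that involve compound 2 cannot be read, so the comparison at this position rests on compound 1 alone.

The compounds shown leave open how far compound 3 lies beyond its limit. They also leave open whether a morpholin-4-yl or a benzylamino group on this carbon would bring the number below that of compound 1.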